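The compounds below may be only part of what the source reports. "The series", "measured", "known", "first", "only" and "open" are said of these compounds alone.

Of the compounds shown here, three sharing one core have been tested in a functional assay on MCF7 cells (Homo sapiens) for cytotoxicity, read by MTT assay, with a stated time of 96 h; a lower number here means a stronger inhibitor, a higher number a weaker inhibitor. Compound 1 `COc1cc(C(=O)c2cn(-c3cccc(C)c3)cc2-c2cccc([N+](=O)[O-])c2)cc(OC)c1OC` gives 880 nM. Compound 2 `COc1cc(C(=O)c2cn(-c3cccc(C)c3)cc2-c2cccc(N)c2)cc(OC)c1OC` gives 130 nM, and compound 3 `COc1cc(C(=O)c2cn(-c3cccc(C)c3)cc2-c2ccc(N)cc2)cc(OC)c1OC` gives 18 nM. Compound 2 therefore stands second highest of the three numbers: the step of a 6.8-fold lower number from compound 1 to compound 2 (0.83 log units; beyond the scatter) separates it from compound 1, and the step of a 7.2-fold lower number from compound 2 to compound 3 (0.86 log units; beyond the scatter) separates it from compound 3, which has the lowest number here.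

Compound 4 `COc1cc(C(=O)c2cn(-c3ccc(N)cc3)cc2-c2cccc(N)c2)cc(OC)c1OC` has not yet been measured. It differs from compound 2 in a single place: 4-aminophenyl in place of 3-methylphenyl on an aromatic nitrogen. Within the data shown here, all of the measured steps concern the group on an aromatic carbon: a 6.8-fold lower number from compound 1 to compound 2 (0.83 log units; beyond the scatter), a 7.2-fold lower number from compound 2 to compound 3 (0.86 log units; beyond the scatter) and a 49-fold lower number from compound 1 to compound 3 (1.69 log units; beyond the scatter). None of them changes the group on the aromatic nitrogen, so they bear on this step only loosely; they do show that an amino group, and especially a 4-aminophenyl group, on an aromatic carbon went with lower numbers. Among the measured compounds shown here, with no direct precedent, only a small lowering, possibly within the scatter, is expected: a 1.4-fold lower number from compound 2 to compound 4 (0.16 log units; within the scatter). Compound 4 is thus estimated at 90 nM, with a range from 25 nM to 350 nM.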

Compound 4, half-maximal inhibitory concentration: 78 nM
Beside the measured number, compound 4's estimate is 1.2-fold (0.06 log units) above it; the measured number falls inside the stated range.
By their numbers in this assay, from the lowest: compound 3; then compounds 4 and 2 (each within the scatter of the next); then compound 1.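

The step of a 1.7-fold lower number from compound 2 to compound 4 (0.22 log units; within the scatter) is the first shown at the group on the aromatic nitrogen, and it stays inside the usual scatter of repeated measurements. Compound 2 and compound 4 therefore cannot be told apart here, even though 4-aminophenyl brings a nitrogen, a hydrogen-bond donor and a hydrogen-bond acceptor that 3-methylphenyl lacks, so this position tolerates the swap in this assay. Nothing measured here explains that result.

This swap changes both the group on the ring (amino for methyl) and its place on the ring, and a 3-aminophenyl or 4-methylphenyl group on the aromatic nitrogen would separate the two. From the compounds shown here alone, it also remains open how this position responds to groups further from these, such as an unsubstituted phenyl, a 4-methoxyphenyl or a carboxylic acid on the ring.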